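A few compounds are considered here, and "the series" means these few. Any claim that something is new, unique, unknown or untested is made for them only; others in the source may bear on it.

Among the compounds with values here, compound 2 `C=CCn1c(=O)/c(=C\c2cccc(Cl)c2)[nH]c(=O)/c1=C\c1ccccc1OC` gives, in a functional assay on Huh-7 cells (Homo sapiens) for cytotoxicity, read by CCK-8 assay, with a stated time of 72 h (on this read-out higher numbers stand for weaker inhibition and lower numbers for stronger inhibition), 8900 nM, the lowest of the two numbers measured so far; its only neighbour, compound 1 `C=CCn1c(=O)/c(=C\c2ccccc2F)[nH]c(=O)/c1=C\c1ccccc1OC`, gives 31300 nM in this assay. Compound 3 `C=CCn1c(=O)/c(=C\c2cccc(Cl)c2Cl)[nH]c(=O)/c1=C\c1ccccc1OC` differs from compound 2 by chloro in place of hydrogen on an aromatic carbon. Within the data shown here, the single measured step, a 3.5-fold lower number from compound 1 to compound 2 (0.55 log units; beyond the scatter), also swapped the aromatic ring on that chain carbon and was modest, but no measured pair adds a second chloro, so the bearing is loose. The step of a 1.5-fold lower number from compound 2 to compound 3 (0.17 log units; within the scatter) is therefore expected to be small, leaning toward a lower number. Compound 3 is estimated at 6000 nM, within 2500 nM to 15000 nM.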

Compound 3, half-maximal inhibitory concentration: 1200 nM
Compound 3: middle estimate off by 5.0-fold (0.70 log units), on the high side; measured number outside the range, below it.
By their numbers in this assay, from the lowest: compound 3; then compound 2; then compound 1.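

A second chloro on an aromatic carbon, ortho to a chloro group, changes a single place on the ring, and in this assay it gives a 7.4-fold lower number from compound 2 to compound 3 (0.87 log units; beyond the scatter), so this position responds clearly to that one added atom. Taken against the 2-fluorophenyl ring, the 2,3-dichlorophenyl ring gives a 26-fold lower number from compound 1 to compound 3 (1.42 log units; beyond the scatter), a large step. Nothing available explains why the number falls. On these data alone, whether bromo or a methyl group in place of that second chloro would give a similar number remains open.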